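This account rests on a few compounds, and the source may have more. Where it says the series, first, only, none or still open, it means among the compounds named here.

Compound 2 has the structure `COc1cc(-c2cc(/C=C/C(=O)c3ccccc3)nc3cc(-c4ccccc4)nn23)cc(OC)c1OC`. In an ADME assay on HEK293 cells (Homo sapiens) for antiproliferative activity, read by MTT assay, with a stated time of 24 h (a higher number here means a weaker inhibitor, a lower number a stronger inhibitor), compound 2 gives >= 100000 nM, which is a limit of the assay and not a number, so its position is known only as a bound. Within the data shown here, its one measured neighbour, compound 1 with structure `COc1cc(C(=O)/C=C/c2cc(-c3cc(OC)c(OC)c(OC)c3)n3nc(-c4ccccc4)cc3n2)cc(OC)c1OC`, is the same case. In this assay compound 1 gives >= 100000 nM, again a limit. The step that the two limits leave unreadable from compound 1 to compound 2 is therefore of unreadable size. Compound 3, with structure `COc1cc(-c2cc(/C=C/C(=O)c3ccc(C)c(C)c3)nc3cc(-c4ccccc4)nn23)cc(OC)c1OC`, has not been measured in this assay. It differs from compound 2 by 3,4-dimethylphenyl in place of phenyl on a carbonyl carbon. Among the measured compounds shown here, the only measured step runs between two limits (the limit of >= 100000 nM in this assay, at which 2 of the 2 values shown sit), so neither a direction nor a size can be taken from it, and the expected step from compound 2 to compound 3 is a number no higher from compound 2 to compound 3 (the limit leaves the size open), nothing beyond the scatter. Compound 3 is thus expected to give about 100000 nM in this assay, within 40000 nM to 300000 nM, and most likely once more only as a limit.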

Compound 3, half-maximal inhibitory concentration: 72500 nM
The estimate for compound 3 lay 1.4-fold (0.14 log units) above the measured number, and the stated range covers the measured number.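

In this assay, compound 3 is the only one of the compounds shown to give a number and not a limit, so 3,4-dimethylphenyl on the carbonyl carbon yields a reading on the scale where phenyl and 3,4,5-trimethoxyphenyl yielded none. The change reads as an at least 1.3-fold lower number from compound 2 to compound 3 (0.13 log units; that floor lies within the scatter) and as an at least 1.3-fold lower number from compound 1 to compound 3 (0.13 log units; that floor lies within the scatter), so each step has only a floor, and neither floor shows a change beyond the usual scatter. The true size of both steps stays open because the other two compounds remain bounded: the limit of >= 100000 nM in this assay, at which 2 of the 3 values shown sit.

The compounds shown leave open whether a single methyl on the phenyl ring would also give a reading. They also leave open what an amine or a carboxylic acid on that ring would give.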